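Losing the 2-oxopropyl group from compound 3

The source may hold more compounds than are shown below. What is called first, only, known or untested is meant among the compounds shown, and "the series" means these compounds.

Compound 1 `COC(=O)CCN1CCN(c2c(F)cc3c(=O)c(C(=O)O)cn(C4CC4)c3c2OC)CC1C`: > 1000 ug/mL
Compound 2 `COc1c(N2CCN(CC(C)=O)C(C)C2)c(F)cc2c(=O)c(C(=O)O)cn(C3CC3)c12`: 500 ug/mL
Compound 3 `COc1c(N2CCN(CCC(C)=O)C(C)C2)c(F)cc2c(=O)c(C(=O)O)cn(C3CC3)c12`: 9.84 ug/mL

These values come from an ADME assay on Vero cells (Chlorocebus sabaeus) for cytotoxicity, read by MTT assay, with a stated time of 72 h; on this read-out higher numbers stand for lower toxicity in this test and lower numbers for higher toxicity in this test. For compound 1 the value > 1000 ug/mL is a limit of the assay and not a number. Compound 3 stands lowest at 9.84 ug/mL, and the nearest number belongs to compound 2 at 500 ug/mL.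

Compound 4 `COc1c(N2CCN(C/C(C)=N/NC(N)=O)C(C)C2)c(F)cc2c(=O)c(C(=O)O)cn(C3CC3)c12` has not yet been measured. Its structure differs from that of compound 3 in one place: a group of 7 heavy atoms (3 carbon, 3 nitrogen, 1 oxygen; no ring) in place of a group of 4 heavy atoms (3 carbon, 1 oxygen; no ring), on a saturated chain carbon bound to an amine nitrogen in a ring. The most relevant measured change is the one that introduced the departing 2-oxopropyl group, a 51-fold lower number from compound 2 to compound 3 (1.71 log units; beyond the scatter). The comparison with the limit points the same way, an at least 100-fold lower number from compound 1 to compound 3 (2.00 log units; beyond the scatter). Within the data shown here, no measured compound carries the entering group, so the full size of those steps cannot be assumed to reverse. A rise in this assay is nevertheless expected, and the estimated change is a 15-fold higher number from compound 3 to compound 4 (1.18 log units; beyond the scatter). For compound 4 the estimate is 150 ug/mL. The expected range for compound 4 is 20 ug/mL to 1000 ug/mL.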

Compound 4, half-maximal cytotoxic concentration: 500 ug/mL
Compound 4: the middle estimate sits 3.3-fold (0.52 log units) below what was measured; the range from low to high includes it.
By their numbers in this assay, from the lowest: compound 3; then compounds 2 and 4 (each within the scatter of the next). At a limit, above all of these: compound 1.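

In this assay, the group of 7 heavy atoms in place of 2-oxopropyl gives a 51-fold higher number from compound 3 to compound 4 (1.71 log units; beyond the scatter), so the low number of compound 3 does not hold for every group at this place, on a saturated chain carbon bound to an amine nitrogen in a ring. Against the acetyl-bearing compound 2, the same group gives no change at the digits printed from compound 2 to compound 4 (within the scatter), which leaves compound 3 alone at the low end of this set. Against compound 1, only a floor can be read, an at least 2.0-fold lower number from compound 1 to compound 4 (0.30 log units; that floor lies within the scatter), as its value is a limit of the assay: the limit of > 1000 ug/mL in this assay, at which 1 of the 4 values shown sits.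

The step from compound 3 changes both the chain and its end, so the share of each remains unresolved. Going by these compounds, a longer chain ending in the same group, or in an amine or a carboxylic acid, remains open.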